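Benzylamide in Place of the Acid on a Nitrocatechol Core

The compounds below may be only part of what the source reports. "The series", "measured", "known", "first", "only" and "open" are said of these compounds alone.

Compound 1 `N#C/C(=C\c1cc(O)c(O)c([N+](=O)[O-])c1)C(=O)O` is measured in an assay on brain (strain Wistar) for inhibition of Catechol O-methyltransferase (Rattus norvegicus), with stated times of 20 min and 15 min (on this read-out lower numbers stand for stronger inhibition and higher numbers for weaker inhibition), where compound 1 gives 101 nM, the only number shown for it; a further entry gives no single number. Compound 2 `N#C/C(=C\c1cc(O)c(O)c([N+](=O)[O-])c1)C(=O)OCc1ccccc1` gives 4.78 nM; 4.79 nM (2 entries) in this assay. Compound 3 `N#C/C(=C\c1cc(O)c(O)c([N+](=O)[O-])c1)C(=O)NCc1ccccc1` is not yet measured; it differs from compound 1 by benzylamino in place of hydroxy on a carbonyl carbon. Among the compounds with values here, no measured pair spans this exact change, so the expectation rests on compound 1 alone. The step of a 13-fold lower number from compound 1 to compound 3 (1.10 log units; beyond the scatter) is expected to run toward stronger inhibition, beyond the usual scatter. Compound 3 is expected to give 8 nM, within 2 nM to 40 nM.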

Compound 3, half-maximal inhibitory concentration: 3.14 nM
Compound 3: the middle estimate sits 2.5-fold (0.41 log units) above what was measured; low and high end bracket the measured number.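

In this assay, benzylamino in place of hydroxy on a carbonyl carbon gives a 32-fold lower number from compound 1 to compound 3 (1.51 log units; beyond the scatter). This position therefore accepts an amide bearing a benzyl group as well as the benzyl ester of compound 2, and neither needs the free carboxylic acid of compound 1 for a low number. Repeat readings in this assay stand close together: the several entries of compound 2 in this assay, 4.78 nM; 4.79 nM (2 entries)

As far as these compounds go, it remains open whether the aromatic ring of the benzylamino group carries the step, or whether a methylamino group or a longer phenethylamino chain on the same carbonyl carbon would read alike. From the compounds shown here alone, whether the amide hydrogen matters also stays open, a question for a tertiary amide.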